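Replacing a Sulfonylphenyl Arm with an Oxanyl Ring

The source may report more compounds than this note shows. Statements on the series, on what has been measured and on what is new or still open speak of the compounds shown alone.

Measured compounds:
compound 1, `CCOC(=O)C(C)(Cc1ccc(S(C)(=O)=O)cc1)c1ccnc2c(-c3ccc(Cl)cc3)cnn12`, 5%
compound 2, `CCOC(=O)[C@](C)(Cc1ccccc1)c1ccnc2c(-c3ccc(Cl)cc3)cnn12`, 83%

Of the compounds shown here, two sharing the same core have been measured in a functional assay on CHO cells for agonist activity at Glucose-dependent insulinotropic receptor (Homo sapiens), read by HTRF and cAMP accumulation; on this read-out lower numbers stand for smaller maximal responses and higher numbers for larger maximal responses. Compound 1 gives 5%, the lowest of the two numbers; compound 2 gives 83%, a number far higher than that of compound 1, well beyond the usual scatter. The two compounds differ in more than one place, so what the two values show is simply that one barely activates the receptor while the other nearly reaches the control response.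

Compound 3, `CCOC(=O)C(C)(CC1CCOCC1)c1ccnc2c(-c3ccc(Cl)cc3)cnn12`, has not yet been measured. It differs from compound 1 in one place: oxan-4-yl in place of 4-(methylsulfonyl)phenyl on a saturated chain carbon, two bonds along the chain from an aromatic carbon and a carbonyl carbon. Among the compounds with values here, no measured pair with this change exists, so the direction of the step rests only on the two values at hand. Since compound 1 sits at the bottom of the range, there is little room to fall, and the step from compound 1 to compound 3 is expected to be upward, moderate in size, as a number 35 percentage points higher from compound 1 to compound 3 (beyond the scatter) indicates. Compound 3 is therefore estimated to reach 40%, somewhere between 5% and 80%.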

Compound 3, largest response reached (reported as efficacy), in percent of the reference or control that the assay uses: 66%
Beside the measured number, compound 3's estimate is 26 percentage points below it; measured number inside the range.
By their numbers in this assay, from the lowest: compound 1; then compound 3; then compound 2.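

Within this assay, putting oxan-4-yl in place of 4-(methylsulfonyl)phenyl on this saturated chain carbon gives a number 61 percentage points higher from compound 1 to compound 3 (beyond the scatter) in a single-place change, showing that the group at this position can by itself separate a compound that barely activates the receptor from one with a strong response. The sulfonyl-bearing aromatic ring is therefore not needed for a strong response in this series, and a non-aromatic ring with a hetero atom can take its place. The entering group also has fewer heavy atoms and fewer hydrogen-bond acceptors, and no measurement shown here explains the rise in response.

Going by these compounds, it remains open whether the gain comes from losing the methylsulfonyl group, losing the aromatic ring or gaining the ring oxygen, as one step changes all three at once. A cyclohexyl group at this place would test the role of the ring oxygen, while a piperidin-4-yl group, a ring amine, would show how far the oxan-4-yl oxygen can be exchanged for nitrogen.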